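A few compounds are considered here, and "the series" means these few. Any claim that something is new, unique, unknown or untested is made for them only; others in the source may bear on it.

Measured so far in an in vitro ADME assay on microsomes from liver (Mus musculus, strain CD1) for metabolic stability, read by HPLC, with a stated time of 4 h; a higher number here means faster removal of the compound, a lower number slower removal:
- compound 1 `CCOC(=O)c1c(-c2cccc(Oc3ccccc3)c2)[nH]c2cc(OC)ccc2c1=O` gives 35 mL.min-1.g-1
- compound 2 `CCOC(=O)c1c(-c2cccc(Oc3ccccc3)c2)[nH]c2cc(OC)c(F)cc2c1=O` gives 16 mL.min-1.g-1
- compound 3 `CCOC(=O)c1c(-c2cccc(Cl)c2)[nH]c2cc(OC)c(F)cc2c1=O` gives 4 mL.min-1.g-1

Compound 2 holds the middle place among these three numbers, lower than compound 1 and higher than compound 3. Compound 4 `COc1cc2[nH]c(-c3cccc(Oc4ccccc4)c3)c(C(=O)OCCO)c(=O)c2cc1F` has not yet been measured. It carries 2-hydroxyethyl where compound 2 has ethyl, with hydroxy in place of hydrogen on a saturated chain carbon (hydroxy in place of hydrogen on a saturated chain carbon, two bonds along the chain from an oxygen next to a carbonyl group).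

Among the compounds with values here, two measured steps touch compound 2. One (a 2.2-fold lower number from compound 1 to compound 2 (0.34 log units; beyond the scatter)) came with fluoro in place of hydrogen on an aromatic carbon, the other (a 4.0-fold lower number from compound 2 to compound 3 (0.60 log units; beyond the scatter)) with chloro in place of phenoxy on an aromatic carbon. Both are modest and beyond the scatter, but neither alters the chain, so they suggest a size and not a direction. A step no larger than these is therefore expected, leaning slightly towards a lower number. The expected step is thus (a 1.3-fold lower number from compound 2 to compound 4 (0.12 log units; within the scatter)). Compound 4 is estimated at 12 mL.min-1.g-1 (expected range 5 mL.min-1.g-1 to 30 mL.min-1.g-1).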

Compound 4, intrinsic clearance in microsomes: 11 mL.min-1.g-1
Compound 4: middle estimate off by 1.1-fold (0.04 log units), on the high side; measured number inside the range.
By their numbers in this assay, from the lowest: compound 3; then compounds 4 and 2 (each within the scatter of the next); then compound 1.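

On the ester chain, the change to 2-hydroxyethyl in this assay gives only a small step (a 1.5-fold lower number from compound 2 to compound 4 (0.16 log units; within the scatter)), so hydroxy in place of hydrogen at this saturated chain carbon leaves the read-out within the scatter. The two earlier steps (a 2.2-fold lower number from compound 1 to compound 2 (0.34 log units; beyond the scatter)) and (a 4.0-fold lower number from compound 2 to compound 3 (0.60 log units; beyond the scatter)) lay beyond the scatter, and both were changes on aromatic carbons. This position is thus the only one shown so far where a change produces no readable difference, although it rests on a single pair of compounds.

Nothing measured here accounts for this result. On these data alone, it remains open whether an amine, a carboxylic acid or a longer chain at this position would behave the same way, and whether hydroxy would read alike with chloro in place of phenoxy, as in compound 3.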